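This account rests on a few compounds, and the source may have more. Where it says the series, first, only, none or still open, it means among the compounds named here.

Three compounds have been measured in a functional assay on A549 cells (Homo sapiens) for antiproliferative activity, read by MTT assay, with a stated time of 72 h; on this read-out higher numbers stand for weaker inhibition and lower numbers for stronger inhibition:

Compound 1 `CC(C)OC1=C(C(=O)c2ccccc2)C(c2ccc(Br)cc2)N(CCCn2ccnc2)C1=O` gives 8720 nM.
Compound 2 `CCCCCOC1=C(C(=O)c2ccccc2)C(c2ccc(Br)cc2)N(CCCn2ccnc2)C1=O` gives 7290 nM.
Compound 3 `CCCCOC1=C(C(=O)c2ccccc2)C(c2ccc(Br)cc2)N(CCCn2ccnc2)C1=O` gives 18500 nM.

Among these three, compound 3 stands at the highest number. The step of a 2.1-fold higher number from compound 1 to compound 3 (0.33 log units; beyond the scatter) and the step of a 2.5-fold higher number from compound 2 to compound 3 (0.40 log units; beyond the scatter) both set compound 3 apart from the other two beyond the scatter, whereas a 1.2-fold lower number from compound 1 to compound 2 (0.08 log units; within the scatter) leaves compounds 1 and 2 within the scatter of each other.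

Compound 4 `O=C(C1=C(Nc2ccccc2)C(=O)N(CCCn2ccnc2)C1c1ccc(Br)cc1)c1ccccc1` has not yet been measured in this assay. It differs from compound 3 in one place: anilino in place of butoxy on a double-bonded ring carbon. Going by the values given here, none of the measured steps covers a change of this kind; all three exchange one chain on the oxygen for another, and even the larger of them, a 2.5-fold higher number from compound 2 to compound 3 (0.40 log units; beyond the scatter), is only modest. The replacement of the whole butoxy group by anilino lies outside what those steps show, so the expectation has to rest on the narrow spread of the three measured numbers rather than on a matching precedent. Compound 4 is therefore expected to land near the measured compounds, with a wide range: 9000 nM, between 2500 nM and 35000 nM. This estimate amounts to an expected step of a 2.1-fold lower number from compound 3 to compound 4 (0.31 log units; beyond the scatter).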

Compound 4, half-maximal inhibitory concentration: 24100 nM
Compound 4: the middle estimate sits 2.7-fold (0.43 log units) below what was measured, and the stated range covers the measured number.
By their numbers in this assay, from the lowest: compounds 2 and 1 (each within the scatter of the next); then compounds 3 and 4 (each within the scatter of the next).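

In this assay, the change from an oxygen-linked chain to a nitrogen-linked aromatic ring at this double-bonded ring carbon gives (  a 1.3-fold higher number from compound 3 to compound 4 (0.11 log units; within the scatter)  ), so this much larger exchange, which also brings in a hydrogen-bond donor, leaves the number within the scatter of the butoxy compound. Against the other two ethers, the same exchange gives (  a 3.3-fold higher number from compound 2 to compound 4 (0.52 log units; beyond the scatter)  ) and (  a 2.8-fold higher number from compound 1 to compound 4 (0.44 log units; beyond the scatter)  ), both modest steps, so anilino at this position falls in with butoxy and apart from pentyloxy and isopropoxy, and the ether chains do not all differ from it alike. No supporting data bear on why these numbers fall as they do.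

The compounds shown leave open whether the linking atom or the phenyl ring decides the outcome, since the two change together in compound 4, and a butylamino group or a phenoxy group at this carbon would separate them. They also leave open whether an anilino ring carrying a chloro or methoxy group, or a benzylamino group, would move the number in either direction.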